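Aryl substituent change at the sulfonyl group

This account rests on a few compounds, and the source may have more. Where it says the series, first, only, none or still open, it means among the compounds named here.

Measured so far in an assay on isolated protein for displacement of a labelled ligand from metabotropic glutamate receptor 5 (Homo sapiens), with a stated time of 60 min, tested at 1 uM; a higher number here means more inhibition at the concentration tested (going by the name of the read-out), a lower number less inhibition:
- compound 1, `CC1CCN(c2c(S(=O)(=O)c3cc(F)cc(F)c3)cnc3cc(Cl)ccc23)CC1`, gives 94%
- compound 2, `CC1CCN(c2c(S(=O)(=O)c3cccc(Cl)c3)cnc3cc(Cl)ccc23)CC1`, gives 92%
- compound 3, `CC1CCN(c2c(S(=O)(=O)c3cccc(Cl)c3)cnc3ccc(Cl)cc23)CC1`, gives 92%

All three sit at a high level of inhibition. Compound 2 and compound 3 read the same at the digits shown, and compound 1 lies within the scatter of both, so the three numbers cannot be told apart. Within the data shown here, the one single-point step among them, a number 2 percentage points lower from compound 1 to compound 2 (within the scatter), is within the scatter.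

Compound 4, `CC1CCN(c2c(S(=O)(=O)c3cccc(C#N)c3)cnc3cc(Cl)ccc23)CC1`, is not yet measured. It differs from compound 2 as follows: cyano in place of chloro on an aromatic carbon.

Among the measured compounds shown here, only one measured step touches the aryl group on the sulfonyl sulfur, a number 2 percentage points lower from compound 1 to compound 2 (within the scatter), and it shows that swapping halogens on that ring left the read-out unchanged beyond the scatter. For the measured compounds named here, no measured compound carries a cyano group, so the present change has no direct precedent. On the evidence that the aryl substituent at this position has so far made no difference, the expectation for compound 4 is a step of about a number 2 percentage points lower from compound 2 to compound 4 (within the scatter), that is, none beyond the scatter. The estimate for compound 4 in this assay is 90%, with a range from 78% to 97%.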

Compound 4, a percentage reported as inhibition, at one concentration (the size of the read-out at that concentration, not a potency): 94%
The estimate for compound 4 lay 4 percentage points below the measured number; the range from low to high includes it.
By their numbers in this assay, from the lowest: compounds 2, 3, 1 and 4 (each within the scatter of the next).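

In this assay, the change from 3-chlorophenyl to 3-cyanophenyl gives a number 2 percentage points higher from compound 2 to compound 4 (within the scatter), and replacing 3,5-difluorophenyl on the sulfonyl sulfur with 3-cyanophenyl gives no change at the digits printed from compound 1 to compound 4 (within the scatter). The earlier step compared halogen-bearing aryl groups only, whereas these two show that the read-out also stays within the scatter with a non-halogen group on the aromatic carbon, here cyano, with its 2 heavy atoms and 1 hydrogen-bond acceptor. No measurement available here accounts for this lack of separation between the compounds.

All four compounds read high at a single concentration, so these numbers cannot show whether their potencies differ, and the comparison at this position extends only to chloro, fluoro and cyano. Still open, going by these compounds, is whether an amine or a carboxylic acid on this aryl group would move the read-out beyond the scatter, and whether the cyano group would behave the same way on the core of compound 3, where the chloro group on the core sits elsewhere.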